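The source may hold more compounds than are shown below. What is called first, only, known or untested is meant among the compounds shown, and "the series" means these compounds.

Compound 1 `CC1=CC[C@@H]([C@@](C)(O)CCCC(C)(C)NC(=S)N/N=C\c2ccc(C)cc2)CC1`: 45700 nM
Compound 2 `CC1=CC[C@@H]([C@@](C)(O)CCCC(C)(C)NC(=S)N/N=C\c2ccccc2Cl)CC1`: > 100000 nM, a limit of the assay
Compound 3 `CC1=CC[C@@H]([C@@](C)(O)CCCC(C)(C)NC(=S)N/N=C\c2cccc(Cl)c2)CC1`: 37800 nM

In a functional assay on PCO3 cells (Homo sapiens) for cytotoxicity, read by sulforhodamine B assay (on this read-out higher numbers stand for weaker inhibition of growth and lower numbers for stronger inhibition of growth), compound 1 gives 45700 nM, the higher of the two plain numbers. Compound 3 sits close, with a 1.2-fold lower number from compound 1 to compound 3 (0.08 log units; within the scatter). For compound 2 the value > 100000 nM is a limit, not a number, as the limit of > 100000 nM in this assay, at which 1 of the 3 values shown sits, shows.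

Compound 4 `CC1=CC[C@@H]([C@@](C)(O)CCCC(C)(C)NC(=S)N/N=C\c2ccc(Cl)cc2)CC1` differs from compound 1 by chloro in place of methyl on an aromatic carbon. Among the compounds with values here, no measured step covers chloro at this place. The steps of an at least 2.1-fold higher number from compound 1 to compound 2 (0.34 log units; beyond the scatter) and an at least 2.6-fold lower number from compound 2 to compound 3 (0.42 log units; beyond the scatter) show that where the chloro sits matters, yet 3-chlorophenyl gave a 1.2-fold lower number from compound 1 to compound 3 (0.08 log units; within the scatter). The expected step is therefore a 1.1-fold lower number from compound 1 to compound 4 (0.06 log units; within the scatter), within the scatter. Compound 4 is estimated at 40000 nM, between 15000 nM and 100000 nM.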

Compound 4, concentration for total growth inhibition: 22700 nM
For compound 4 the middle estimate is 1.8-fold (0.25 log units) above the measured one, within the range that was stated.
By their numbers in this assay, from the lowest: compounds 4, 3 and 1 (each within the scatter of the next). At a limit, above all of these: compound 2.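

In this assay, chloro in place of methyl on this aromatic carbon gives a 2.0-fold lower number from compound 1 to compound 4 (0.30 log units; within the scatter), so swapping these two groups at this place stays inside the usual noise. Moving the chloro gives a 1.7-fold lower number from compound 3 to compound 4 (0.22 log units; within the scatter) and an at least 4.4-fold lower number from compound 2 to compound 4 (0.64 log units; beyond the scatter), so among the three chlorinated compounds only the 2-chlorophenyl one, compound 2, stands apart. Compound 2 remains a limit, not a number: the limit of > 100000 nM in this assay, at which 1 of the 4 values shown sits.

The compounds shown leave open whether an amine or a carboxylic acid at this place would keep the number in the same range. They also leave open how a methoxy group would behave there.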